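The source may hold more compounds than are shown below. What is called first, only, known or untested is meant among the compounds shown, and "the series" means these compounds.

Compound 1 `COc1ccc(/C=C/C(=O)c2ccc(N)c(-c3ccc(F)cc3)c2)cc1`: 4310 nM
Compound 2 `COc1cccc(/C=C/C(=O)c2cccc(-c3cccc(F)c3)c2)c1OC`: 8900 nM
Compound 3 `O=C(/C=C/c1cccc(Br)c1)c1cccc(-c2cccc(F)c2)c1`: 9120 nM

These three compounds were tested in a functional assay on A549 cells (Homo sapiens) for cytotoxicity, read by sulforhodamine B assay, with a stated time of 48 h; on this read-out higher numbers stand for weaker inhibition and lower numbers for stronger inhibition. Compound 3, at 9120 nM, cannot be told apart from compound 2, at 8900 nM, since the two values lie within the scatter of each other. Compound 1 has a lower number, 4310 nM, and its gap to compound 3 lies beyond the scatter, so compound 3 stands at the weak end of this small set, together with compound 2.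

The next compound is compound 4 `COc1ccc(/C=C/C(=O)c2cccc(-c3cccc(F)c3)c2)cc1`, which has 4-methoxyphenyl in place of 3-bromophenyl on a double-bonded chain carbon bound to a double-bonded chain carbon. Among the compounds with values here, no measured pair differs in only one place, so the size of this step cannot be read directly from the data. Compound 1 also carries 4-methoxyphenyl and gives 4310 nM, but it differs from compound 4 elsewhere as well, so it offers only a loose guide. Compound 2 gives 8900 nM. On this basis, the expected 1.3-fold lower number from compound 3 to compound 4 (0.11 log units; within the scatter) is small, slightly towards stronger inhibition, and is not expected to go beyond the scatter. For compound 4, the estimated value is 7000 nM, with an expected range of 2500 nM to 20000 nM.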

Compound 4, half-maximal inhibitory concentration: 2440 nM
Compound 4: the middle estimate sits 2.9-fold (0.46 log units) above what was measured; measured number below the stated range.
By their numbers in this assay, from the lowest: compounds 4 and 1 (each within the scatter of the next); then compounds 2 and 3 (each within the scatter of the next).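

In this assay, within the data shown here, the change from 3-bromophenyl to 4-methoxyphenyl on a double-bonded chain carbon bound to a double-bonded chain carbon gives a 3.7-fold lower number from compound 3 to compound 4 (0.57 log units; beyond the scatter) and is the first change in this set that can be read on its own. Among these compounds, none of the earlier compounds differed in only one place, so only now is it clear that this position responds to the group it carries, with the number moving beyond the scatter towards stronger inhibition while the rest of the structure stays fixed. The step exchanges one whole group for another, so it cannot separate the departure of the bromine from the arrival of the methoxy group or from the different place of each on the ring, and no measurement offered here accounts for the direction of the change.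

On these data alone, it remains open whether a hydroxyl or a dimethylamino group in place of the methoxy group would keep the lower number at this position. As far as these compounds go, it is also open whether the same exchange would give a step of similar size on the core of compound 1, which carries an amine.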